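Fluoro to Bromo: Expected Cytotoxicity on Vero Cells

This account rests on a few compounds, and the source may have more. Where it says the series, first, only, none or still open, it means among the compounds named here.

Measured compounds:
Compound 1 `COc1ccc(/C=C(\C)C(=O)/C=C/c2ccc(/C=C/C(=O)/C(C)=C/c3ccc(OC)cc3)cc2)cc1`: 460000 nM
Compound 2 `COc1ccc(/C=C(\C)C(=O)/C=C/c2ccccc2F)cc1`: 81200 nM

In an ADME assay on Vero cells (Chlorocebus sabaeus) for cytotoxicity, read by MTT assay, with a stated time of 72 h (on this read-out higher numbers stand for lower toxicity in this test and lower numbers for higher toxicity in this test), compound 1 gives 460000 nM. In this assay compound 2 gives 81200 nM, the lower of the two numbers; compound 1 sits at a higher number, and that gap lies beyond the usual scatter. Compound 3 `COc1ccc(/C=C(\C)C(=O)/C=C/c2ccccc2Br)cc1` has not yet been measured in this assay. It differs from compound 2 in one place: bromo in place of fluoro on an aromatic carbon.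

For the measured compounds named here, no step between measured compounds is available to guide this change. Exchanging one halogen for another on the same aromatic carbon is a modest change, so a step of no more than the usual scatter is expected, with, if anything, a slightly lower number. The step expected a 1.2-fold lower number from compound 2 to compound 3 (0.10 log units; within the scatter) is therefore small. Compound 3 is estimated to give 65000 nM, with a range from 28000 nM to 150000 nM.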

Compound 3, half-maximal cytotoxic concentration: 71000 nM
Beside the measured number, compound 3's estimate is 1.1-fold (0.04 log units) below it; the measured number falls inside the stated range.
By their numbers in this assay, from the lowest: compounds 3 and 2 (each within the scatter of the next); then compound 1.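

In this assay, for the compounds shown here, the first step at this position reads a 1.1-fold lower number from compound 2 to compound 3 (0.06 log units; within the scatter) and stays within the usual scatter, so compound 2 and compound 3 cannot be told apart in this test. The earlier compounds shown here offered no step between compounds differing in one place, whereas this pair shows that bromo in place of fluoro on an aromatic carbon, ortho to a large group, leaves the read-out where it was. No measured evidence bears on this result.

On these data alone, whether an amine or a carboxylic acid on this same aromatic carbon would give a step beyond the scatter remains open. As far as these compounds go, it also remains open whether the exchange of fluoro for bromo would read the same way on another aromatic carbon of the shared core.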